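A few compounds are considered here, and "the series" means these few. Any claim that something is new, unique, unknown or untested is made for them only; others in the source may bear on it.

Compound 1 `CCOC(=O)CNc1nc(Nc2ccccc2)ncc1[N+](=O)[O-]`: > 100000 nM
Compound 2 `CCOC(=O)CNc1nc(NCc2ccccc2)ncc1[N+](=O)[O-]`: 52400 nM

In a functional assay on MCF7 cells (Homo sapiens) for antiproliferative activity, read by MTT assay, with a stated time of 48 h (on this read-out lower numbers stand for stronger inhibition and higher numbers for weaker inhibition), compound 2 gives 52400 nM, the only number among the two results shown. Compound 1 reaches only a limit of the assay, > 100000 nM, as noted in the limit of > 100000 nM in this assay, at which 1 of the 2 values shown sits. For the measured compounds named here, the one measured step is an at least 1.9-fold lower number from compound 1 to compound 2 (0.28 log units; that floor lies within the scatter), where benzyl replaces phenyl. Compound 3 `CCOC(=O)CNc1nc(Nc2cccc(OC)c2)ncc1[N+](=O)[O-]` differs from compound 2 by 3-methoxyphenyl in place of benzyl on a nitrogen on an aromatic ring, which returns an aryl group to that nitrogen, as in compound 1. Compound 3 is therefore expected to run against the measured step, with a 2.1-fold higher number from compound 2 to compound 3 (0.32 log units; beyond the scatter) in the direction of weaker inhibition and a real chance of only a limit. The estimate for compound 3 is 110000 nM, within 40000 nM to 300000 nM.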

Compound 3, half-maximal inhibitory concentration: 35800 nM
Beside the measured number, compound 3's estimate is 3.1-fold (0.49 log units) above it; the measured number lies below the stated range.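

In this assay, methoxy in place of hydrogen on an aromatic carbon gives an at least 2.7-fold lower number from compound 1 to compound 3 (0.44 log units; beyond the scatter), the first step shown that clears the scatter. Compound 1 stands at a limit, so this step is only a floor: the limit of > 100000 nM in this assay, at which 1 of the 3 values shown sits. Exchanging benzyl for 3-methoxyphenyl on the nitrogen gives a 1.5-fold lower number from compound 2 to compound 3 (0.17 log units; within the scatter), so the two groups are not separated at this position. Left open is how an amine or a hydroxyl group in place of methoxy would read in this assay. On these data alone, a longer chain between the nitrogen and the ring also remains open.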